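Methyl Added Near a Fused Ring: Solubility Outlook

The source may report more compounds than this note shows. Statements on the series, on what has been measured and on what is new or still open speak of the compounds shown alone.

Measured compounds:
compound 1 `Cc1nn(C)cc1-c1cnc2[nH]cc(-c3cccc(C#N)c3)c2c1` 2000 nM
compound 2 `Cc1nn(C)c(C)c1-c1cnc2[nH]cc(-c3cccc(C#N)c3)c2c1` 5700 nM
compound 3 `N#Cc1cccc(-c2n[nH]c3ncc(-c4cnn(C5CCOCC5)c4)cc23)c1` 700 nM

In a physicochemical assay for solubility, read by LC-MS, in phosphate buffer, measured as thermodynamic solubility, with a stated time of 24 h, at pH 7.4 (on this read-out lower numbers stand for lower solubility and higher numbers for higher solubility), compound 3 gives the lowest of the three numbers. The difference between the core of compound 3 and the core of compound 1 is not broken down here. Compound 2 differs from compound 1 by methyl in place of hydrogen on an aromatic carbon, and this gave a 2.9-fold higher number from compound 1 to compound 2 (0.45 log units; beyond the scatter). Compound 4 `Cc1c(-c2cnn(C3CCOCC3)c2)cnc2[nH]nc(-c3cccc(C#N)c3)c12` differs from compound 3 by methyl in place of hydrogen on an aromatic carbon. It is the same kind of change, but around a different place: in compound 2 the methyl sits on a five-membered aromatic ring with 2 nitrogen, next to the ring nitrogen, whereas in compound 4 it sits on a six-membered aromatic ring with 1 nitrogen, ortho to a fused ring and ortho to a large group. Going by the values given here, the step is expected to be a 2.1-fold higher number from compound 3 to compound 4 (0.33 log units; beyond the scatter), a somewhat smaller rise than the earlier one, resting only on the single step of a 2.9-fold higher number from compound 1 to compound 2 (0.45 log units; beyond the scatter) seen so far. Compound 4 is therefore estimated at 1500 nM.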

Compound 4, solubility: 2000 nM
Estimate against measurement, compound 4: 1.3-fold (0.12 log units) below, and the stated range covers the measured number.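

In this assay, methyl in place of hydrogen on an aromatic carbon gave a 2.9-fold higher number from compound 3 to compound 4 (0.46 log units; beyond the scatter) and, on the other core, a 2.9-fold higher number from compound 1 to compound 2 (0.45 log units; beyond the scatter) in a step of nearly the same printed size, so the rise carried across these two cores. This rests on a single pair for each core, with the methyl on a different ring in each pair, and it does not show that the rise would hold on any further core. Nothing shown here accounts for the rise in either pair.

As far as these compounds go, whether ethyl, an amine or a carboxylic acid in place of that hydrogen would give a similar rise stays open. So does the outcome of methyl on other aromatic carbons of either core.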